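Trimming the Dichlorobenzyl Amide in a Cytotoxic Series

A few compounds are considered here, and "the series" means these few. Any claim that something is new, unique, unknown or untested is made for them only; others in the source may bear on it.

Compound 1, `NCCCNc1c(C(=O)NCc2ccc(F)cc2)nc(Br)c2cccnc12`, in a functional assay on HCT-116 cells (Homo sapiens) for cytotoxicity, read by MTT assay, with a stated time of 72 h (a higher number here means a weaker inhibitor, a lower number a stronger inhibitor), gives > 20000 nM, which is a limit of the assay and not a number.
Compound 2, `CN(C)CCCNc1c(C(=O)NCc2ccc(F)cc2)nc(Br)c2cccnc12`, gives > 10000 nM, again a limit rather than a number.
Compound 3, `N[C@H]1CC[C@H](Nc2c(C(=O)NCc3ccc(Cl)cc3Cl)nc(Br)c3cccnc23)CC1`, gives 6000 nM.

Among the compounds with values here, compound 3 therefore holds the only measured number among the three; the other two sit at limits, one at the limit of > 20000 nM in this assay, at which 1 of the 3 values shown sits, and one at the limit of > 10000 nM in this assay, at which 1 of the 3 values shown sits. Within the data shown here, the single step that can be read between measured compounds, a step that the two limits leave unreadable from compound 1 to compound 2, changes the amine-bearing chain, and the two limits leave its size unreadable. It says nothing about the benzyl amide, which is where compound 4, `N[C@H]1CC[C@H](Nc2c(C(=O)NCc3ccccc3)nc(Br)c3cccnc23)CC1`, departs from compound 3: phenyl in place of 2,4-dichlorophenyl on a saturated chain carbon bound to an amide-type nitrogen.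

Among the measured compounds shown here, no measured step bears on this change, so the expectation for compound 4 rests on compound 3 alone. Compound 4 is expected to be a weaker inhibitor than compound 3, with the estimated step of a 2.5-fold higher number from compound 3 to compound 4 (0.40 log units; beyond the scatter) in this assay, though the shift is not expected to be large. Compound 4 is thus estimated at 15000 nM, within a range from 4000 nM to 40000 nM, and a reading that stops at a limit would not be surprising.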

Compound 4, half-maximal inhibitory concentration: 7000 nM
Compound 4: the middle estimate sits 2.1-fold (0.33 log units) above what was measured, within the range that was stated.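

Replacing 2,4-dichlorophenyl with phenyl, on a saturated chain carbon bound to an amide-type nitrogen, gives a 1.2-fold higher number from compound 3 to compound 4 (0.07 log units; within the scatter) in this assay, so the two chlorine atoms of the 2,4-dichlorobenzyl group make no difference that can be told from the scatter in this pair. Within the data shown here, this is the first readable step and the first to bear on the benzyl amide, since the earlier step concerned the amine-bearing chain and could not be read; the pair also shows that the plain benzyl amide keeps compound 4 level with compound 3 on the shared core and the same aminocyclohexyl-type amine. Nothing at hand gives a cause for this step.

What the compounds shown leave open is whether a single chlorine on the benzyl ring, a methoxy group in its place, or a longer chain such as phenethyl would also stay level with compound 3 and compound 4. As far as these compounds go, it is also open whether the same indifference to the benzyl substituent would hold with the open-chain amines of compound 1 and compound 2, since the values of both are limits of the assay and not numbers.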